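Swapping the ring on the pyrrole nitrogen for an aminophenyl

A few compounds are considered here, and "the series" means these few. Any claim that something is new, unique, unknown or untested is made for them only; others in the source may bear on it.

Measured so far:
- compound 1, `COc1cc(C(=O)c2cn(-c3cccc(C)c3)cc2-c2cccc(N)c2)cc(OC)c1OC`: 130 nM
- compound 2, `COc1cc(C(=O)c2cn(-c3cccc(C)c3)cc2-c2ccc(N)cc2)cc(OC)c1OC`: 18 nM

In a functional assay on MCF7 cells (Homo sapiens) for cytotoxicity, read by MTT assay, with a stated time of 96 h (on this read-out higher numbers stand for weaker inhibition and lower numbers for stronger inhibition), compound 2 stands lowest of the two numbers, and its nearest neighbour is compound 1, separated by a 7.2-fold lower number from compound 1 to compound 2 (0.86 log units; beyond the scatter). Compound 3, `COc1cc(C(=O)c2cn(-c3ccc(N)cc3)cc2-c2ccc(N)cc2)cc(OC)c1OC`, keeps everything of compound 2 except one change: 4-aminophenyl in place of 3-methylphenyl on an aromatic nitrogen. For the measured compounds named here, no measured step touches this position; the only step known, from compound 1 to compound 2, concerns the other aryl ring, so it gives no direct guide here. Compound 2 already carries the same 4-aminophenyl and gives 18 nM. A second copy on the ring nitrogen is taken as a modest risk rather than a gain. Compound 3 is therefore expected to give about 40 nM in this assay, within 8 nM to 200 nM, a step of a 2.2-fold higher number from compound 2 to compound 3 (0.35 log units; beyond the scatter) that is expected to stay near the scatter.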

Compound 3, half-maximal inhibitory concentration: 15 nM
Compound 3: the middle estimate sits 2.7-fold (0.43 log units) above what was measured; low and high end bracket the measured number.
By their numbers in this assay, from the lowest: compounds 3 and 2 (each within the scatter of the next); then compound 1.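

In this assay, placing 4-aminophenyl on the aromatic nitrogen in place of 3-methylphenyl gives a 1.2-fold lower number from compound 2 to compound 3 (0.08 log units; within the scatter) and so leaves the two compounds indistinguishable on this read-out. For the compounds shown here, this is the first view of this position, and it shows that the ring on the nitrogen can change from 3-methylphenyl to 4-aminophenyl without a shift beyond the scatter. Nothing available explains this outcome.

Moving the amino group on the other aryl ring gave a 7.2-fold lower number from compound 1 to compound 2 (0.86 log units; beyond the scatter) and whether its placement matters as much on the nitrogen-bound ring remains open, as a 3-aminophenyl group there would show. Also open, as far as these compounds go, is how a plain phenyl ring, a carboxylic acid or a longer carbon chain would fare at this nitrogen.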